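Removing one methoxy from the aromatic ring of compound 1

This account rests on a few compounds, and the source may have more. Where it says the series, first, only, none or still open, it means among the compounds named here.

Among the measured compounds shown here, compound 1 `COC(=O)N1N=C(c2ccccc2)CC1c1cc(OC)c(OC)c(OC)c1` gives 2180 nM in a functional assay on HeLa cells (Homo sapiens) for antiproliferative activity, read by MTT assay, with a stated time of 48 h (a lower number here means a stronger inhibitor of growth, a higher number a weaker inhibitor of growth), the lowest of the two numbers known. Compound 2 `CCOC(=O)N1N=C(c2ccccc2)CC1c1cc(OC)c(OC)c(OC)c1` gives 8230 nM, the step of a 3.8-fold higher number from compound 1 to compound 2 (0.58 log units; beyond the scatter) being the only measured one. Compound 3 `COC(=O)N1N=C(c2ccccc2)CC1c1ccc(OC)c(OC)c1` differs from compound 1 by hydrogen in place of methoxy on an aromatic carbon. For the measured compounds named here, no measured step touches the aromatic ring, so the change is judged without a direct precedent; the one known step concerns the ester chain only. Compound 3 is expected to give a higher number, 6500 nM between 2500 nM and 20000 nM. The step of a 3.0-fold higher number from compound 1 to compound 3 (0.47 log units; beyond the scatter) is thus estimated to lie beyond the scatter.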

Compound 3, concentration for 50% growth inhibition: 5480 nM
For compound 3 the middle estimate is 1.2-fold (0.07 log units) above the measured one, within the range that was stated.
By their numbers in this assay, from the lowest: compound 1; then compounds 3 and 2 (each within the scatter of the next).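

The change gives a 2.5-fold higher number from compound 1 to compound 3 (0.40 log units; beyond the scatter) in this assay. Among the compounds shown here, this is the first measured change on the aromatic ring, and it shows that the number responds to this position, not only to the ester chain: with hydrogen in place of methoxy, growth inhibition is weaker by more than the scatter. No measurement at hand explains this step.

From the compounds shown here alone, whether a hydroxyl group or an amine at this place would match methoxy remains open. So does the effect of removing either of the two methoxy groups that remain in compound 3.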